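The compounds below may be only part of what the source reports. "The series", "measured", "known", "first", "only" and "open" are said of these compounds alone.

Of the compounds shown here, three built on one shared core have been measured in a functional assay on CHO cells with adenosine receptor A1 (Homo sapiens) as the target, read by cAMP accumulation and immunoassay, with a stated time of 6 min, tested at 0.01 uM; a lower number here means a stronger effect, a higher number a weaker effect of the compound at the concentration tested. Compound 1 `Nc1scc(CN2CCN(c3ccc(Cl)cc3Cl)CC2)c1C(=O)c1ccc(Cl)cc1` gives 2%, compound 2 `Nc1scc(CN2CCN(c3cccc(C(F)(F)F)c3)CC2)c1C(=O)c1ccc(Cl)cc1` gives -8.2%, and compound 3 `Nc1scc(CN2CCN(C3CCCCCC3)CC2)c1C(=O)c1ccc(Cl)cc1` gives 2.9%, the highest of the three numbers, although its gap to compound 1 lies within the scatter and only compound 2 sits beyond it. Compound 4 `Nc1scc(CN2CCN(c3ccc(F)c(Cl)c3)CC2)c1C(=O)c1ccc(Cl)cc1` has not yet been measured; it differs from compound 3 by 3-chloro-4-fluorophenyl in place of cycloheptyl on an amine nitrogen in a ring. Going by the values given here, two measured steps bear on this change, since each also exchanged cycloheptyl against a ring on the same nitrogen: a number 0.9 percentage points higher from compound 1 to compound 3 (within the scatter) and a number 11.1 percentage points higher from compound 2 to compound 3 (beyond the scatter). Read backwards, they point to no change or a modest fall, so a step of a number 4.9 percentage points lower from compound 3 to compound 4 (within the scatter) is expected. Compound 4 is therefore estimated at -2%, with a range from -14% to 10%.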

Compound 4, a percentage reported as activity, at one concentration (the size of the read-out at that concentration, not a potency): 4.2%
Beside the measured number, compound 4's estimate is 6.2 percentage points below it, within the range that was stated.
By their numbers in this assay, from the lowest: compound 2; then compounds 1, 3 and 4 (each within the scatter of the next).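

The change from cycloheptyl to 3-chloro-4-fluorophenyl on the amine nitrogen gives a number 1.3 percentage points higher from compound 3 to compound 4 (within the scatter), so in this assay this aromatic ring and the non-aromatic carbon ring cannot be told apart at this position. The new group also cannot be told apart from 2,4-dichlorophenyl, with a number 2.2 percentage points higher from compound 1 to compound 4 (within the scatter), whereas 3-(trifluoromethyl)phenyl stays set apart, with a number 12.4 percentage points higher from compound 2 to compound 4 (beyond the scatter). No supporting data bear on the reason for this pattern. From the compounds shown here alone, what an unsubstituted phenyl, a carboxylic acid or a longer chain on this nitrogen would give stays open.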